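The source may report more compounds than this note shows. Statements on the series, on what has been measured and on what is new or still open speak of the compounds shown alone.

Working notes on the series.

Compound 3 `CSc1nc(NCc2ccccc2)c2cccnc2n1` carries a phenyl on a saturated chain carbon bound to a nitrogen on an aromatic ring. In a functional assay on HT-29 cells (Homo sapiens) for cytotoxicity, read by MTT assay, with a stated time of 72 h (on this read-out lower numbers stand for higher toxicity in this test and higher numbers for lower toxicity in this test), compound 3 reaches only the limit of the assay, > 100000 nM, and no number. Compound 1 `CSc1nc(NCCCCCO)c2cccnc2n1` differs from it by 4-hydroxybutyl in place of phenyl on a saturated chain carbon bound to a nitrogen on an aromatic ring. In this assay compound 1 likewise sits at a limit, > 100000 nM. The step that the two limits leave unreadable from compound 3 to compound 1 therefore cannot be read, because both values rest on (the limit of > 100000 nM in this assay, at which 3 of the 3 values shown sit).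

Compound 2 `CSc1nc(NCc2ccccc2)c2ccccc2n1` is built on a different core; the difference between the two cores is not broken down here. In this assay compound 2 also gives a limit, > 100000 nM. The change to compound 4 `CSc1nc(NCCCCCO)c2ccccc2n1` is 4-hydroxybutyl in place of phenyl on a saturated chain carbon bound to a nitrogen on an aromatic ring, the same change as from compound 3 to compound 1, at the same place.

For the measured compounds named here, since every value so far rests on (the limit of > 100000 nM in this assay, at which 3 of the 3 values shown sit), the step from compound 2 to compound 4 is expected to be about a step that the limit leaves unreadable from compound 2 to compound 4, that is, unreadable. Compound 4 is expected near 120000 nM in this assay, with a range from 40000 nM to 300000 nM, most likely again a limit.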

Compound 4, concentration lethal to 50% of the cells: > 100000 nM
Compound 4: only a limit was reported; the forecaster's own chance of this, stated with the estimate: 85%; the middle value does not contradict the limit.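

Compound 4 gives only a limit in this assay, > 100000 nM. The step from compound 2 to compound 4 therefore cannot be read, because both values rest on the same limit: the limit of > 100000 nM in this assay, at which 4 of the 4 values shown sit.

The compounds shown leave open whether phenyl, 4-hydroxybutyl or either core makes any difference in this assay, as none of the four gives a number.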